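The source may hold more compounds than are shown below. What is called first, only, known or untested is meant among the compounds shown, and "the series" means these compounds.

Measured compounds:
Compound 1 `CN(c1ccccc1)S(=O)(=O)c1ccc(NC(=O)c2ccc(Cl)cc2Cl)cc1` gives 2570 nM in a functional assay on HEK293 cells for agonist activity at probable G-protein coupled receptor 27 (Homo sapiens), read by a luciferase reporter and beta-arrestin recruitment, with a stated time of 10 min; on this read-out higher numbers stand for an effect only at larger amounts of compound and lower numbers for an effect already at smaller amounts.
Compound 2 `COc1ccc(NS(=O)(=O)c2ccc(NC(=O)c3ccc(Cl)cc3Cl)cc2)cc1` reaches only the limit of this assay, > 100000 nM.
Compound 3 `Cc1ccc(NS(=O)(=O)c2ccc(NC(=O)c3ccc(Cl)cc3Cl)cc2)cc1` likewise reaches only the limit of this assay, > 100000 nM.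

Compound 3 therefore stands at the upper limit of this assay, with no number of its own, and it shares that limit with one other value in the set (the limit of > 100000 nM in this assay, at which 2 of the 3 values shown sit). The change to compound 4 `Cc1ccccc1NS(=O)(=O)c1ccc(NC(=O)c2ccc(Cl)cc2Cl)cc1` is small on paper: 2-methylphenyl in place of 4-methylphenyl on a sulfonamide nitrogen. The steps already measured speak mostly about the sulfonamide nitrogen. The step of an at least 38-fold higher number from compound 1 to compound 3 (1.59 log units; beyond the scatter) and the step of an at least 38-fold higher number from compound 1 to compound 2 (1.59 log units; beyond the scatter) both show that replacing methyl(phenyl)amino by an aryl-amino group carrying a hydrogen on the nitrogen sends the value to the limit. The step that the two limits leave unreadable from compound 2 to compound 3 between the two limits cannot be read. Among the compounds with values here, compound 4 keeps the hydrogen on the sulfonamide nitrogen and only shifts the methyl on the aryl ring, so no measured step suggests a return toward the number of compound 1. Compound 4 is thus expected to remain near the limit, giving an estimated step of an at least 1.1-fold lower number from compound 3 to compound 4 (0.04 log units; that floor lies within the scatter). The estimate for compound 4 is 90000 nM, with a range from 15000 nM to 300000 nM, and most likely a limit is reported again.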

Compound 4, half-maximal effective concentration: 1230 nM
Estimate against measurement, compound 4: 73-fold (1.86 log units) above; measured number below the stated range.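

In this assay, the earlier reading that a hydrogen on the sulfonamide nitrogen by itself sends the value to the limit does not hold, since 2-methylphenyl in place of 4-methylphenyl gives an at least 81-fold lower number from compound 3 to compound 4 (1.91 log units; beyond the scatter). The comparison with the 4-methoxyphenyl compound points the same way, with an at least 81-fold lower number from compound 2 to compound 4 (1.91 log units; beyond the scatter), and compound 4 also keeps that hydrogen yet goes past the methyl(phenyl)amino compound, with a 2.1-fold lower number from compound 1 to compound 4 (0.32 log units; beyond the scatter), a modest step though one beyond the scatter. At this place, then, where the methyl sits on the aryl ring decides as much as the hydrogen does, so 2-methylphenyl and 4-methylphenyl cannot be treated as interchangeable here.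

From the compounds shown here alone, compound 2 and compound 3 each give only a limit of the assay, not a number, so the step between them cannot be read and how far either lies from compound 4 stays unknown beyond its printed floor: the limit of > 100000 nM in this assay, at which 2 of the 4 values shown sit. Whether the gain holds for other groups on the sulfonamide nitrogen, such as 2-methoxyphenyl or 2-ethylphenyl, stays open, as does the effect of adding a methyl to the sulfonamide nitrogen of compound 4.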